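Replacing a Ring-Methylene Amine with a Carbamoyl Cyclobutyl Amine

The compounds below may be only part of what the source reports. "The series", "measured", "known", "first", "only" and "open" are said of these compounds alone.

Within the data shown here, compound 2 `N#Cc1cnc(NCc2cnccc2C(F)(F)F)cc1NCC1CCOCC1` gives 400 nM in an assay on isolated protein for inhibition of protein kinase C theta type (Homo sapiens), read by TR-FRET, with a stated time of 2 h (a lower number here means a stronger inhibitor, a higher number a weaker inhibitor), the highest of the two numbers so far. Among the measured compounds shown here, compound 1 `CO[C@H]1CC[C@@H](Nc2cc(NCc3cnccc3C(F)(F)F)ncc2C#N)CC1` gives 58 nM in this assay, and the single measured step is a 6.9-fold higher number from compound 1 to compound 2 (0.84 log units; beyond the scatter). Compound 3 `CC1(C)[C@@H](C(N)=O)C[C@H]1Nc1cc(NCc2cnccc2C(F)(F)F)ncc1C#N` is not yet measured; it differs from compound 2 by 3-carbamoyl-2,2-dimethylcyclobutyl in place of (oxan-4-yl)methyl on a nitrogen on an aromatic ring. The step from compound 1 to compound 2 bears on this change only loosely: it shows that a change of the group on this nitrogen moved the number by a modest amount, and that the directly attached ring in compound 1 came with the lower number. Compound 3 again carries a directly attached ring, so the expectation is a modest fall in this assay, written as a 3.3-fold lower number from compound 2 to compound 3 (0.52 log units; beyond the scatter). Compound 3 is therefore estimated to give 120 nM in this assay, with a range from 30 nM to 450 nM.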

Compound 3, half-maximal inhibitory concentration: 1.4 nM
For compound 3 the middle estimate is 86-fold (1.93 log units) above the measured one; measured number below the stated range.
By their numbers in this assay, from the lowest: compound 3; then compound 1; then compound 2.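

In this assay the group on this nitrogen proves to matter far more than the earlier pair suggested: 3-carbamoyl-2,2-dimethylcyclobutyl in place of (oxan-4-yl)methyl gives a 290-fold lower number from compound 2 to compound 3 (2.46 log units; beyond the scatter) and so goes well beyond the modest earlier step. The same group in place of 4-methoxycyclohexyl gives a 41-fold lower number from compound 1 to compound 3 (1.62 log units; beyond the scatter) on the same core, so a directly attached ring alone does not set the number. Against (oxan-4-yl)methyl, the entering group brings a hydrogen-bond donor, a four-membered carbon ring and defined stereocentres together, and these compounds cannot separate their shares. Nothing measured here explains the size of this gain.

The compounds shown leave open whether a carboxylic acid or a methyl ester could stand in for the carbamoyl group. Also open, on these data alone, are the need for the two methyl groups and the effect of the other stereoisomers of the cyclobutyl ring.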